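A few compounds are considered here, and "the series" means these few. Any claim that something is new, unique, unknown or untested is made for them only; others in the source may bear on it.

The shared core of these compounds carries a sugar-like ring and a fused bicyclic head group, and the three made so far vary only in the aromatic tail at one end. Compound 1 `CCCCCc1ccc(-c2cc3cn([C@H]4C[C@H](O)[C@@H](CO)O4)c(=O)nc3o2)cn1` bears a pentyl chain on a nitrogen-containing six-membered ring, and in an ADME assay on HEL cells (Homo sapiens) for cytotoxicity, with a stated time of 3 days (a higher number here means that more compound is tolerated, a lower number that less compound is tolerated), compound 1 gives 100000 nM. Compound 2 `CCCCCc1ccc(-c2cc3cn([C@H]4C[C@H](O)[C@@H](CO)O4)c(=O)nc3o2)cc1` has the same pentyl chain on a ring of carbon only, and for compound 2 this assay reaches only a limit, > 1300 nM. Compound 3 `Cc1ccc(C#Cc2cc3cn([C@H]4C[C@H](O)[C@@H](CO)O4)c(=O)nc3o2)cc1` joins the tail to the core through an ethynyl linker ending in a 4-methylphenyl group, and for compound 3 too the result is a limit, >= 510000 nM. Compound 3 therefore stands at the upper edge of what has been measured, where one of the three values sits (the limit of >= 510000 nM in this assay, at which 1 of the 3 values shown sits), while the other limit lies much lower (the limit of > 1300 nM in this assay, at which 1 of the 3 values shown sits).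

Compound 4 `O=c1nc2oc(C#Cc3ccccc3)cc2cn1[C@H]1C[C@H](O)[C@@H](CO)O1` is compound 3 with one change: hydrogen in place of methyl on an aromatic carbon. For the measured compounds named here, no measured pair differs in one place, so no direct precedent exists for this step. Removing a single methyl is a small change, and the step from compound 3 to compound 4 in this assay is expected to be small, none beyond the scatter, an at least 1.2-fold lower number from compound 3 to compound 4 (0.10 log units; that floor lies within the scatter). Compound 4 is estimated to be tolerated at 400000 nM, within a range from 100000 nM to 600000 nM.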

Compound 4, minimum cytotoxic concentration: > 570000 nM
Compound 4 gave a limit, no number; the forecaster's own chance of this, stated with the estimate: 70%; middle value at least 1.4-fold (0.15 log units) away from the limit.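

In this assay, compound 3 and compound 4 each give only a limit, not a number, and the step from one to the other cannot be read. The compounds shown leave open how much of either compound is tolerated, and whether going from 4-methylphenyl to phenyl changes that amount at all.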